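Chloro for hydrogen on a fused core: compound 3 to 4

The source may hold more compounds than are shown below. What is called first, only, known or untested is meant among the compounds shown, and "the series" means these compounds.

Measured compounds:
compound 1, `ClCc1ccccc1Cn1cnc2c(Cl)nc(Cl)nc21`, in a functional assay on HCC 2998 cells (Homo sapiens) for cytotoxicity, read by sulforhodamine B assay, with a stated time of 48 h; on this read-out higher numbers stand for weaker inhibition of growth and lower numbers for stronger inhibition of growth: 3380 nM
compound 2, `ClCc1cccc(Cn2cnc3ncnc(Cl)c32)c1`, in this assay: 3230 nM
compound 3, `ClCc1cccc(Cn2cnc3c(Cl)ncnc32)c1`, in this assay: 1730 nM

Compound 3 has the lowest of the three numbers, but its gaps to compound 2 and to compound 1 both lie within the usual scatter, so no order among the three can be read from them. Compound 4, `ClCc1cccc(Cn2cnc3c(Cl)nc(Cl)nc32)c1`, has not yet been measured in this assay. It differs from compound 3 in one place: chloro in place of hydrogen on an aromatic carbon, the new chloro sitting between two ring nitrogen atoms, meta to a chloro group, meta to a fused ring and para to a fused ring. Within the data shown here, no step between measured compounds of this kind is available. Compound 1, whose core carries a comparable pair of chloro groups, gives a number within the scatter of compound 3, which gives little reason to expect a large move. The step from compound 3 to compound 4 is therefore expected to be small, a 1.3-fold higher number from compound 3 to compound 4 (0.10 log units; within the scatter), and not clearly beyond the scatter in either direction. Compound 4 is estimated to give 2200 nM, within a range from 800 nM to 6000 nM.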

Compound 4, concentration for total growth inhibition: 3160 nM
Compound 4: middle estimate off by 1.4-fold (0.16 log units), on the low side; low and high end bracket the measured number.
By their numbers in this assay, from the lowest: compounds 3, 4, 2 and 1 (each within the scatter of the next).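

In this assay, the position between two ring nitrogen atoms now has a step of its own: chloro in place of hydrogen gives a 1.8-fold higher number from compound 3 to compound 4 (0.26 log units; within the scatter). The earlier compounds shown here offered no step at this position, and this first one shows that the core can carry the added chloro there with no difference that can be told from the scatter. Nothing measured here bears on why the step is this small.

On these data alone, whether an amine, a methoxy group or a longer alkyl chain at this position would give a step beyond the scatter remains open. The compounds shown also leave open whether the step from hydrogen to chloro would read the same way on other cell lines.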